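From pyridin-3-yl to pyridin-2-yl on a shared core

The source may report more compounds than this note shows. Statements on the series, on what has been measured and on what is new or still open speak of the compounds shown alone.

compound 1 `CCCCCCCCc1ccc(OCC(=O)Cn2nnc(-c3cccc(Cl)c3)n2)cc1` gives 69%
compound 2 `CCCCCCCCc1ccc(OCC(=O)Cn2nnc(-c3ccc(S(=O)(=O)N(C)C)cc3)n2)cc1` gives 65%
compound 3 `CCCCCCCCc1ccc(OCC(=O)Cn2nnc(-c3cccnc3)n2)cc1` gives 12%

All three values come from an ADME assay on S9 fraction from liver (Rattus norvegicus) for metabolic stability, read by LC-MS, using NADPH, with a stated time of 30 min (a higher number here means that more of the compound is left, a lower number that less of the compound is left), and compound 3 stands lowest of them. The next structure, compound 4 `CCCCCCCCc1ccc(OCC(=O)Cn2nnc(-c3ccccn3)n2)cc1`, has the same atoms as compound 3, joined differently: pyridin-2-yl in place of pyridin-3-yl on an aromatic carbon. In words, pyridin-2-yl sits in place of pyridin-3-yl on an aromatic carbon of the five-membered aromatic ring with 4 nitrogen.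

Two measured steps show that exchanging this group can matter greatly: a number 57 percentage points lower from compound 1 to compound 3 (beyond the scatter) and a number 53 percentage points lower from compound 2 to compound 3 (beyond the scatter). The third, a number 4 percentage points lower from compound 1 to compound 2 (within the scatter), shows that an exchange here can also leave the number almost unmoved. Going by the values given here, none of these steps only shifts the ring nitrogen, so no direct precedent exists. Compound 3 is the only measured pyridine, and its 12% leaves far more room upward than downward. A modest rise is therefore expected, and the estimated step is a number 13 percentage points higher from compound 3 to compound 4 (beyond the scatter), with wide uncertainty. For compound 4 the estimated value is 25%, with an expected range from 8% to 60%.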

Compound 4, percent of the compound remaining: 30%
Estimate against measurement, compound 4: 5 percentage points below; low and high end bracket the measured number.
By their numbers in this assay, from the lowest: compound 3; then compound 4; then compounds 2 and 1 (each within the scatter of the next).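

In this assay the location of the ring nitrogen alone counts, with a number 18 percentage points higher from compound 3 to compound 4 (beyond the scatter) for two groups made of the same atoms. That gain closes only part of the gap to the phenyl-bearing compounds, with a number 35 percentage points lower from compound 2 to compound 4 (beyond the scatter) and a number 39 percentage points lower from compound 1 to compound 4 (beyond the scatter) still, so neither pyridine comes close to the 3-chlorophenyl or 4-(dimethylsulfamoyl)phenyl groups. Nothing shown here explains why moving the nitrogen changes how much compound is left.

Still open, from the compounds shown here alone, is where pyridin-4-yl, the remaining placement of the ring nitrogen, would fall relative to these two pyridines, and whether pyrimidin-2-yl would land nearer the pyridines or the phenyl-bearing compounds. Also open, going by these compounds, is whether the same nitrogen shift would give a similar step with a shorter chain in place of the octyl chain on the shared core.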